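A few compounds are considered here, and "the series" means these few. Any claim that something is new, unique, unknown or untested is made for them only; others in the source may bear on it.

Working notes on the series. The shared core is carried by compound 1 `O=C(/C=C\c1cccc(O)c1)N1N=C(c2ccncc2)OC1c1c[nH]c2ccccc12`, compound 2 `O=C(/C=C\c1ccc(O)cc1)N1N=C(c2ccncc2)OC1c1c[nH]c2ccccc12` and compound 3 `O=C(/C=C\c1ccc(F)cc1)N1N=C(c2ccncc2)OC1c1c[nH]c2ccccc12`. In an ADME assay on A549 cells (Homo sapiens) for cytotoxicity, read by MTT assay, with a stated time of 48 h (on this read-out higher numbers stand for weaker inhibition of growth and lower numbers for stronger inhibition of growth), compound 2 gives > 30 ug/mL, which is a limit of the assay and not a number. Compound 1 likewise gives > 30 ug/mL, a limit. Compound 3 gives > 30 ug/mL, again a limit. All three therefore sit at the limit of > 30 ug/mL in this assay, at which 3 of the 3 values shown sit.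

Compound 4 `O=C(/C=C\c1ccc(Cl)cc1)N1N=C(c2ccncc2)OC1c1c[nH]c2ccccc12` differs from compound 2 by chloro in place of hydroxy on an aromatic carbon. Among the compounds with values here, the steps that bear on this change are a step that the two limits leave unreadable from compound 2 to compound 3 and a step that the two limits leave unreadable from compound 1 to compound 3; both run between limits, so their size is not readable, and the steps a step that the two limits leave unreadable from compound 1 to compound 2 give no more. No step beyond the scatter is expected here. Compound 4 is expected at 40 ug/mL, with a range of 20 ug/mL to 100 ug/mL. The step expected is a step that the limit leaves unreadable from compound 2 to compound 4.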

Compound 4, concentration for 50% growth inhibition: > 30 ug/mL
Compound 4 was reported as a limit; the forecaster's own chance of this, stated with the estimate: 80%; the middle value lies beyond the limit too.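

Compound 4 gives > 30 ug/mL in this assay as a limit, so its steps from compound 1, compound 2 and compound 3 cannot be read. The compounds shown leave open how strongly any of these four inhibits growth, and whether they differ at all.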